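Para substitution on the benzamide of the shared core

This account rests on a few compounds, and the source may have more. Where it says the series, first, only, none or still open, it means among the compounds named here.

Compounds measured so far:
compound 1, `Cc1nc(NC(=O)c2ccccc2)c2nc(-c3ccccc3)sc2n1`, 935 nM in an assay on CHO cells for displacement of a labelled ligand from adenosine receptor A1 (Homo sapiens), read by scintillation counting, with a stated time of 3 h; a lower number here means a stronger inhibitor, a higher number a weaker inhibitor
compound 2, `Cc1nc(NC(=O)c2ccc(Cl)cc2)c2nc(-c3ccccc3)sc2n1`, > 30000 nM

Compound 1 carries an unsubstituted benzamide on the shared core and gives 935 nM in this assay. Compound 2 differs from it only by chloro in place of hydrogen on an aromatic carbon. Compound 2 reaches > 30000 nM, which is a limit of the assay, not a number; it sits at the limit of > 30000 nM in this assay, at which 1 of the 2 values shown sits. Among the compounds with values here, compound 2 therefore stands at the weak end of what has been measured, and the step of an at least 32-fold higher number from compound 1 to compound 2 (1.50 log units; beyond the scatter) is the only measured step.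

Compound 3, `COc1ccc(C(=O)Nc2nc(C)nc3sc(-c4ccccc4)nc23)cc1`, is not yet measured. It differs from compound 2 by methoxy in place of chloro on an aromatic carbon. Within the data shown here, no measured step covers a change from chloro to methoxy; the one step known concerns adding a substituent at the same position, para to a large group, and it was large and toward weaker binding. The estimate for compound 3 below rests on that single step alone.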

Compound 3, inhibition constant: 1460 nM
The estimate for compound 3 lay 10-fold (1.01 log units) above the measured number, outside the stated range (below it).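

The position para to a large group does not punish every substituent in this assay: methoxy is accepted there where chloro is not, with an at least 20-fold lower number from compound 2 to compound 3 (1.31 log units; beyond the scatter). Set against the unsubstituted benzamide, methoxy gives a 1.6-fold higher number from compound 1 to compound 3 (0.19 log units; within the scatter), so compound 1 and compound 3 cannot be told apart, and among the three compounds shown, only chloro carries a large loss at this place. Compound 2 stands as a limit of the assay and not as a number, so the step from it has a lower bound only: the limit of > 30000 nM in this assay, at which 1 of the 3 values shown sits.

With only chloro and methoxy shown at this place, the compounds do not settle whether the loss is particular to chloro or is shared by other groups, and a fluoro, a methyl, an amine or a carboxylic acid could fall on either side of the split. On these data alone, it also remains open whether a longer chain such as ethoxy keeps the number of compound 3 or moves it beyond the scatter, and whether methoxy in place of hydrogen reads the same at other carbons of the benzamide ring.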